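Notes on a thienyl-amide series: pyrazole nitrogen substituent

This account rests on a few compounds, and the source may have more. Where it says the series, first, only, none or still open, it means among the compounds named here.

Measured so far:
- Compound 1, `CCC(CC)N(CCN(C)C(=O)CCC(=O)O)Cc1cccc(C(=O)Nc2sc3c(c2C(=O)c2cnn(-c4ccc(Cl)c(C(F)(F)F)c4)c2)CCC(C)(C)C3)c1`, gives in an assay on isolated protein for inhibition of sodium-dependent phosphate transport protein 2B (Homo sapiens) (on this read-out lower numbers stand for stronger inhibition and higher numbers for weaker inhibition), a value of 38 nM.
- Compound 2, `CCC(CC)N(CCN(C)C(=O)CCC(=O)O)Cc1cccc(C(=O)Nc2sc3c(c2C(=O)c2cnn(-c4ccc(Cl)cc4)c2)CCN(S(C)(=O)=O)C3)c1`, gives in this assay a value of 2490 nM.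

Compound 1 stands at the lowest number of the two. Within the data shown here, compound 2 differs from it in more than one place, so its far higher number, beyond the scatter, cannot be tied to any single change; no one-place step between measured compounds exists in this set.

Compound 3, `CCC(CC)N(CCN(C)C(=O)CCC(=O)O)Cc1cccc(C(=O)Nc2sc3c(c2C(=O)c2cnn(Cc4cccc(C(=O)O)c4)c2)CCC(C)(C)C3)c1`, carries 3-carboxybenzyl in place of 4-chloro-3-(trifluoromethyl)phenyl on an aromatic nitrogen. Among the measured compounds shown here, with no measured step on that nitrogen to lean on, the expectation rests on the change alone. The step from compound 1 to compound 3 in this assay is expected to be a 7.9-fold higher number from compound 1 to compound 3 (0.90 log units; beyond the scatter), towards a higher number, beyond the scatter. Compound 3 is accordingly estimated at 300 nM, with a range from 60 nM to 2000 nM.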

Compound 3, half-maximal inhibitory concentration: > 1000 nM
Compound 3 gave a limit, no number; the forecaster's own chance of this, stated with the estimate: 5%; at least 3.3-fold (0.52 log units) between middle value and limit.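

In this assay compound 3 gives > 1000 nM, a limit of the assay and not a number. This gives the series its first readable one-place step: on an aromatic nitrogen of a five-membered aromatic ring with 2 nitrogen, 3-carboxybenzyl in place of 4-chloro-3-(trifluoromethyl)phenyl gives an at least 26-fold higher number from compound 1 to compound 3 (1.42 log units; beyond the scatter), so this position does not take the change without a large loss of inhibition. The full size of the step stays unknown, and the reading ends at the limit: the limit of > 1000 nM in this assay, at which 1 of the 3 values shown sits.

Going by these compounds, the change replaces the whole group, so it remains open whether the loss follows the carboxylic acid, the benzyl link or the departure of the chloro and trifluoromethyl substituents. An unsubstituted benzyl or a 3-aminobenzyl on the core of compound 1 would bear on that question.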